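Hydroxy in place of the amide: cytotoxicity notes

A few compounds are considered here, and "the series" means these few. Any claim that something is new, unique, unknown or untested is made for them only; others in the source may bear on it.

Three amides share one core, shown by compound 1 `C=CC1=C(C(=O)NCc2ccccc2)C(c2ccc(OC)c(OC)c2)OC1`. In a functional assay on A549 cells (Homo sapiens) for cytotoxicity, read by MTT assay, with a stated time of 24 h (a lower number here means a stronger inhibitor, a higher number a weaker inhibitor), compound 1 gives only a limit, > 100000 nM. Compound 2 `C=CC1=C(C(=O)NCCC)C(c2ccc(OC)c(OC)c2)OC1` differs at the chain on the amide-type nitrogen; in this assay compound 2 likewise gives only a limit, > 100000 nM. Compound 3 `C=CC1=C(C(=O)NCc2ccc(Cl)cc2)C(c2ccc(OC)c(OC)c2)OC1` carries a chloro group on an aromatic carbon; in this assay compound 3 again gives only a limit, > 100000 nM. Compound 3 thus stands where the whole series stands so far, at the limit of > 100000 nM in this assay, at which 3 of the 3 values shown sit, and nothing on the numbers separates it from compound 1 or compound 2.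

Compound 4 `C=CC1=C(C(=O)O)C(c2ccc(OC)c(OC)c2)OC1` differs from compound 3 by hydroxy in place of (4-chlorobenzyl)amino on a carbonyl carbon. The measured steps give no reading: a step that the two limits leave unreadable from compound 1 to compound 2, a step that the two limits leave unreadable from compound 1 to compound 3 and a step that the two limits leave unreadable from compound 2 to compound 3. Going by the values given here, none of them removes the amide itself, so no measured step bears directly on this change. In this assay the expected step is therefore a step that the limit leaves unreadable from compound 3 to compound 4, which cannot be placed in either direction beyond the scatter. For compound 4 the estimate in this assay is 150000 nM, most likely another limit. Compound 4 is expected to fall between 40000 nM and 600000 nM.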

Compound 4, half-maximal inhibitory concentration: > 100000 nM
Compound 4 gave a limit, no number; the forecaster's own chance of this, stated with the estimate: 85%; the middle value does not contradict the limit.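

Compound 4 ends up with compounds 1, 2 and 3 in this assay, and none of the steps from those three compounds to compound 4 can be read: the limit of > 100000 nM in this assay, at which 4 of the 4 values shown sit.

The compounds shown leave open whether any change to the shared core gives a readable value in this assay, and how the hydroxy and the amide chains rank against each other.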